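Halogen Position Shifted on the Aryl Ring

The source may hold more compounds than are shown below. What is called first, only, known or untested is meant among the compounds shown, and "the series" means these compounds.

Compound 2 `C=C[C@]1(C)C[C@@H](OC(=O)CNC(=O)Nc2ccc(Cl)cc2)[C@]2(C)[C@H](C)CC[C@]3(CCC(=O)[C@H]32)[C@@H](C)[C@@H]1O` carries a 4-chlorophenyl group on an amide-type nitrogen attached to the shared core. In a functional assay on HT-29 cells (Homo sapiens) for inhibition, read by MTT assay, with a stated time of 72 h (a higher number here means a weaker inhibitor, a lower number a stronger inhibitor), compound 2 gives > 10000 nM, which is a limit of the assay and not a number. Within the data shown here, its one measured neighbour, compound 1 `C=C[C@]1(C)C[C@@H](OC(=O)CNC(=O)Nc2cccc(Br)c2)[C@]2(C)[C@H](C)CC[C@]3(CCC(=O)[C@H]32)[C@@H](C)[C@@H]1O`, bears 3-bromophenyl at the same place; in this assay compound 1 gives > 10000 nM, again a limit. Among the measured compounds shown here, the only measured step, a step that the two limits leave unreadable from compound 1 to compound 2, therefore cannot be sized, as both values sit at the limit (the limit of > 10000 nM in this assay, at which 2 of the 2 values shown sit). Compound 3 `C=C[C@]1(C)C[C@@H](OC(=O)CNC(=O)Nc2ccccc2Br)[C@]2(C)[C@H](C)CC[C@]3(CCC(=O)[C@H]32)[C@@H](C)[C@@H]1O` is the next variation: 2-bromophenyl in place of 4-chlorophenyl on an amide-type nitrogen. For the measured compounds named here, no readable step bears on this change; the sole step available is itself unreadable. The expectation for this assay rests on the two limits alone: compound 3 is expected to come out near the same limit, so that a step that the limit leaves unreadable from compound 2 to compound 3 is expected to be neither larger nor smaller than that. Compound 3 is estimated at 20000 nM, with a range from 5000 nM to 60000 nM.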

Compound 3, half-maximal inhibitory concentration: > 10000 nM
Compound 3 gave a limit, no number (the forecaster's own chance of this, stated with the estimate: 80%); the middle value lies beyond the limit too.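

No step between compound 1, compound 2 and compound 3 can be read, because all three values are limits and not numbers: the limit of > 10000 nM in this assay, at which 3 of the 3 values shown sit.

The compounds shown leave open whether 2-bromophenyl, 3-bromophenyl and 4-chlorophenyl differ at all in this assay, and what change to the shared core would bring a value inside the limit.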